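Swapping the ring on the thiocarbonyl carbon: an expected outcome

This account rests on a few compounds, and the source may have more. Where it says the series, first, only, none or still open, it means among the compounds named here.

Of the compounds shown here, two have been tested in a functional assay on MDA-MB-231 cells (Homo sapiens) for inhibition, read by MTT assay, with stated times of 18 h and 4 h; on this read-out lower numbers stand for stronger inhibition and higher numbers for weaker inhibition. Compound 1 `CCCCCCOP(=O)(O)OCCSC(=S)N1CCCCCC1` gives 17200 nM in this assay. Compound 2 `CCCCCCCCCCOP(=O)(O)OCCSC(=S)N1CCN(C)CC1` gives 29000 nM, which lies within the usual scatter of the number for compound 1, so the two cannot be told apart on these data. Going by the values given here, compound 3 `CCCCCCCCCCOP(=O)(O)OCCSC(=S)N1CCCCCC1` keeps the core of compound 2 and changes only one group: azepan-1-yl in place of 4-methylpiperazin-1-yl on a thiocarbonyl carbon. Among the compounds with values here, no pair of measured compounds differs at this one place, so nothing measured tells how large such a change is. The same azepan-1-yl group also sits on compound 1, whose value sits within the scatter of that of compound 2, which suggests a step no larger than the scatter. The change expected from compound 2 to compound 3 in this assay is therefore a 1.6-fold lower number from compound 2 to compound 3 (0.21 log units; within the scatter), a small move toward a lower number. For compound 3 the estimated value is 18000 nM, with a range from 7000 nM to 45000 nM.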

Compound 3, half-maximal inhibitory concentration: 11400 nM
For compound 3 the middle estimate is 1.6-fold (0.20 log units) above the measured one, within the range that was stated.
By their numbers in this assay, from the lowest: compounds 3, 1 and 2 (each within the scatter of the next, the first and the last beyond it).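

In this assay, azepan-1-yl in place of 4-methylpiperazin-1-yl on a thiocarbonyl carbon now has a measured size: a 2.5-fold lower number from compound 2 to compound 3 (0.41 log units; beyond the scatter) is a modest step, so the ring held at this position does matter in this assay. With azepan-1-yl kept in place, butyl in place of hydrogen on a saturated chain carbon gives a 1.5-fold lower number from compound 1 to compound 3 (0.18 log units; within the scatter), so the two chains cannot be told apart here. On these compounds, the ring swap therefore has a step that can be read, while the chain change does not.

From the compounds shown here alone, it remains open whether piperidin-1-yl or morpholin-4-yl on the thiocarbonyl carbon would match azepan-1-yl or 4-methylpiperazin-1-yl, and what a longer chain would do. Nothing measured here says why the ring swap moves the number.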